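Oxanyl for thiophenyl on the pyridine core of compound 1

The source may hold more compounds than are shown below. What is called first, only, known or untested is meant among the compounds shown, and "the series" means these compounds.

Measured so far:
compound 1, `COc1nc(-c2ccsc2)ccc1[C@@H](c1ccccc1)[C@@](O)(CCN(C)C)c1cccc2ccccc12`, 24.4 ug/mL
compound 2, `COc1ncc(-c2ccccc2)cc1[C@@H](c1ccccc1)[C@@](O)(CCN(C)C)c1cc(F)cc(F)c1`, > 50 ug/mL
compound 3, `COc1ncc(-c2ccccc2)cc1[C@@H](c1ccccc1)[C@@](O)(CCN(C)C)c1ccccc1`, > 50 ug/mL

For the measured compounds named here, in a toxicity assay on Vero cells (Chlorocebus sabaeus) for cytotoxicity (a lower number here means that less compound is tolerated, a higher number that more compound is tolerated), compound 1 gives 24.4 ug/mL, the only number in the set. Compound 2 gives a limit, > 50 ug/mL. Compound 3 likewise gives a limit, > 50 ug/mL, so 2 of 3 values sit at the limit of > 50 ug/mL in this assay, at which 2 of the 3 values shown sit. Going by the values given here, the one measured step, a step that the two limits leave unreadable from compound 2 to compound 3, is at a different place and unreadable, so no measured step bears on the change at hand.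

Compound 4, `COc1nc(C2CCOCC2)ccc1[C@@H](c1ccccc1)[C@@](O)(CCN(C)C)c1cccc2ccccc12`, differs from compound 1 by oxan-4-yl in place of thiophen-3-yl on an aromatic carbon. With no readable step to lean on, a modest move toward the limit is expected rather than a change beyond the scatter. Compound 4 is estimated at 32 ug/mL (range 12 ug/mL to 60 ug/mL), an expected step of a 1.3-fold higher number from compound 1 to compound 4 (0.12 log units; within the scatter).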

Compound 4, half-maximal cytotoxic concentration: > 50 ug/mL
Compound 4 ended at the assay's limit (the forecaster's own chance of this, stated with the estimate: 35%); middle value at least 1.5-fold (0.19 log units) from the limit.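

In this assay, for the compounds shown here, the first readable step at this position is an at least 2.0-fold higher number from compound 1 to compound 4 (0.31 log units; beyond the scatter), with oxan-4-yl in place of thiophen-3-yl on the aromatic carbon next to the ring nitrogen. Compound 4 gives > 50 ug/mL, which is a limit and not a number, so this step has a floor but no measured size. Tolerance at this position therefore responds to the swap of one ring for the other, and the top of the range grows more crowded: the limit of > 50 ug/mL in this assay, at which 3 of the 4 values shown sit.

Whether losing thiophen-3-yl or gaining oxan-4-yl accounts for the step stays open. From the compounds shown here alone, how piperidin-4-yl, an open-chain ether or a carboxylic acid on this carbon would read in this assay also stays open.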